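Methyl to methoxy on the aryl ring of compound 2

The source may hold more compounds than are shown below. What is called first, only, known or untested is meant among the compounds shown, and "the series" means these compounds.

Measured compounds:
Compound 1 `Cc1cccc(-c2nnc(CSc3nnc(/N=C/c4ccccc4O)s3)o2)c1` gives 4550 nM in a functional assay on SMMC-7721 cells (Homo sapiens) for inhibition, read by CCK-8 assay; on this read-out lower numbers stand for stronger inhibition and higher numbers for weaker inhibition.
Compound 2 `Cc1ccc(-c2nnc(CSc3nnc(/N=C/c4ccccc4O)s3)o2)cc1` gives 37100 nM in this assay.

Compound 2 has the highest number of the two measured compounds, that is, the weaker inhibition. Among the compounds with values here, the only measured step, an 8.2-fold higher number from compound 1 to compound 2 (0.91 log units; beyond the scatter), moves the methyl from one position of the aryl ring to another; it does not swap one group for a different one, so it does not bear directly on the change considered here.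

Compound 3 `COc1ccc(-c2nnc(CSc3nnc(/N=C/c4ccccc4O)s3)o2)cc1` arises from compound 2 by methoxy in place of methyl on an aromatic carbon. Within the data shown here, with no measured step that replaces a methyl by a methoxy, there is no basis for expecting a shift in either direction; the change is expected to stay within the scatter of this assay, as a 1.0-fold lower number from compound 2 to compound 3 (0.00 log units; within the scatter). Compound 3 is therefore estimated at 37000 nM, with a range from 12000 nM to 110000 nM.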

Compound 3, half-maximal inhibitory concentration: 10000 nM
For compound 3 the middle estimate is 3.7-fold (0.57 log units) above the measured one, outside the stated range (below it).
By their numbers in this assay, from the lowest: compound 1; then compound 3; then compound 2.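

In this assay, this aromatic carbon proves sensitive to which group it carries, not only to where a methyl sits on the ring: methoxy in place of methyl gives a 3.7-fold lower number from compound 2 to compound 3 (0.57 log units; beyond the scatter). The change recovers only part of the loss seen on moving the methyl, since 4-methoxyphenyl in place of 3-methylphenyl still leaves a 2.2-fold higher number from compound 1 to compound 3 (0.34 log units; beyond the scatter). Nothing measured on these compounds accounts for either difference.

Going by these compounds, whether a methoxy would also lower the number at the ring position that carries the methyl in compound 1 remains open. So does whether an amine, a hydroxyl or a longer chain such as ethoxy on this aromatic carbon would lower the number further or raise it again.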